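From 2,4,6-trifluorophenyl to 2,3,5,6-tetrafluorophenyl

The source may hold more compounds than are shown below. What is called first, only, known or untested is meant among the compounds shown, and "the series" means these compounds.

In a functional assay with Homo sapiens as the target (on this read-out lower numbers stand for stronger inhibition and higher numbers for weaker inhibition), compound 1 `CC(C)[C@H](NC(=O)COc1cccc2ccccc12)C(=O)N[C@@H](CC(=O)O)C(=O)COc1cc(F)cc(F)c1F` gives 11200 nM and compound 2 `CC(C)[C@H](NC(=O)COc1cccc2ccccc12)C(=O)N[C@@H](CC(=O)O)C(=O)COc1c(F)cc(F)cc1F` gives 14900 nM so compound 2 stands level with compound 1 within the scatter. Compound 3 `CC(C)[C@H](NC(=O)COc1cccc2ccccc12)C(=O)N[C@@H](CC(=O)O)C(=O)COc1c(F)c(F)cc(F)c1F` carries 2,3,5,6-tetrafluorophenyl in place of 2,4,6-trifluorophenyl on an oxygen on a saturated carbon. Going by the values given here, only one measured step bears on this change (a 1.3-fold higher number from compound 1 to compound 2 (0.12 log units; within the scatter)), exchanging one trifluorophenyl for another and staying within the scatter. A similarly small step of a 1.2-fold lower number from compound 2 to compound 3 (0.09 log units; within the scatter) is therefore expected, with no firm direction and nothing beyond the scatter. The estimated value for compound 3 is 12000 nM (expected range 6000 nM to 24000 nM).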

Compound 3, half-maximal inhibitory concentration: 6250 nM
Beside the measured number, compound 3's estimate is 1.9-fold (0.28 log units) above it, and the stated range covers the measured number.
By their numbers in this assay, from the lowest: compounds 3, 1 and 2 (each within the scatter of the next, the first and the last beyond it).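

In this assay this position gives its first step beyond the scatter: 2,3,5,6-tetrafluorophenyl in place of 2,4,6-trifluorophenyl on the oxygen brings a modest change (a 2.4-fold lower number from compound 2 to compound 3 (0.38 log units; beyond the scatter)). Read as fluoro in place of hydrogen on an aromatic carbon, the other new step (a 1.8-fold lower number from compound 1 to compound 3 (0.25 log units; within the scatter)) stays within the scatter, so that single fluoro does not separate this pair. Nothing shown accounts for either step.

Going by these compounds, what an unsubstituted phenyl or a pentafluorophenyl would give on this oxygen stays open. So does the effect of a chloro in place of a fluoro on the ring.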